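Adding ethyl to the chain of compound 2

The source may hold more compounds than are shown below. What is called first, only, known or untested is meant among the compounds shown, and "the series" means these compounds.

Compound 1 `CCCCCCCCCCCC(=O)c1cc(O)c(O)c(O)c1` and compound 2 `CCCCCCCCCCCCCCC(=O)c1cc(O)c(O)c(O)c1` share a core and differ only in the length of their saturated chain. In a toxicity assay on Vero cells (Chlorocebus sabaeus) (on this read-out higher numbers stand for weaker inhibition and lower numbers for stronger inhibition), compound 1 gives > 299000 nM, which is a limit of the assay and not a number. Compound 2 gives > 299000 nM, again a limit. Compound 2 therefore has no exact value and stands at the limit of > 299000 nM in this assay, at which 2 of the 2 values shown sit.

The next change leads to compound 3 `CCCCCCCCCCCCCCCCC(=O)c1cc(O)c(O)c(O)c1`. It puts ethyl in place of hydrogen on a saturated chain carbon, ten or more bonds along the chain from a carbonyl carbon.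

For the measured compounds named here, the one measured step that bears on this is a similar change at the same kind of place, a step that the two limits leave unreadable from compound 1 to compound 2. Its size cannot be read, so it offers no sign of a trend in either direction. No step beyond the usual scatter is therefore expected in this assay, and the estimated step is a number no higher from compound 2 to compound 3 (the limit leaves the size open). A further limit is the likeliest report. The estimate for compound 3 is 299000 nM, with an expected range of 100000 nM to 450000 nM.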

Compound 3, half-maximal inhibitory concentration: > 299000 nM
Compound 3: no number, only a limit (the forecaster's own chance of this, stated with the estimate: 85%); the middle value lies on the limit itself.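

Compound 1, compound 2 and compound 3 each give only a limit of the assay and not a number, so no step among them can be read in this assay: the limit of > 299000 nM in this assay, at which 3 of the 3 values shown sit.

The compounds shown leave open whether any saturated chain on the shared core gives an exact value in this assay, and how far these three compounds truly differ.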